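The source may report more compounds than this note shows. Statements on the series, on what has been measured and on what is new or still open speak of the compounds shown alone.

Measured in a functional assay on CCRF-CEM cells (Homo sapiens) for inhibition; a lower number here means a stronger inhibitor, a higher number a weaker inhibitor:
- compound 1 `O=C1O/C(=C\Cn2cc(C(F)(F)F)c(=O)[nH]c2=O)C(OCc2ccccc2)=C1OCc1ccccc1`: 1600 nM
- compound 2 `O=C1O/C(=C\Cn2cc(I)c(=O)[nH]c2=O)C(OCc2ccccc2)=C1OCc1ccccc1`: 3300 nM
- compound 3 `O=C1O/C(=C\Cn2cnc3c(-n4cccc4)ncnc32)C(OCc2ccccc2)=C1OCc1ccccc1`: 5800 nM

Compound 2 lies within the scatter of compound 3, and its number is higher than that of compound 1, beyond the scatter. Compound 4 `O=C1O/C(=C\Cn2cc(Br)c(=O)[nH]c2=O)C(OCc2ccccc2)=C1OCc1ccccc1` differs from compound 2 as follows: bromo in place of iodo on an aromatic carbon. For the measured compounds named here, only one measured step bears on this change: a 2.1-fold higher number from compound 1 to compound 2 (0.31 log units; beyond the scatter), a modest step with iodo in place of trifluoromethyl on an aromatic carbon. Going by the values given here, with only that modest step as a guide, no step beyond the scatter is expected in this assay, with at most a slight drift to a lower number. The estimated step is a 1.3-fold lower number from compound 2 to compound 4 (0.10 log units; within the scatter). For compound 4 the expected value is 2600 nM, with an estimated range of 1300 nM to 5200 nM.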

Compound 4, half-maximal inhibitory concentration: 3500 nM
Compound 4: middle estimate off by 1.3-fold (0.13 log units), on the low side; measured number inside the range.
By their numbers in this assay, from the lowest: compound 1; then compounds 2, 4 and 3 (each within the scatter of the next).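

In this assay, bromo in place of iodo on this aromatic carbon gives a 1.1-fold higher number from compound 2 to compound 4 (0.03 log units; within the scatter) and so does not separate the two halogens. Trifluoromethyl stays apart from both: bromo in its place gives a 2.2-fold higher number from compound 1 to compound 4 (0.34 log units; beyond the scatter) as a second modest step, in the same direction as a 2.1-fold higher number from compound 1 to compound 2 (0.31 log units; beyond the scatter) for iodo. Nothing available explains this difference.

Still open, going by these compounds, is whether an amine, a carboxylic acid or a methyl at this position would read with the halogens or with trifluoromethyl. Also open, on these data alone, is whether a longer chain here would be tolerated.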